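This account rests on a few compounds, and the source may have more. Where it says the series, first, only, none or still open, it means among the compounds named here.

Four compounds share a core in which a six-membered ring bearing one nitrogen is fused to an aromatic ring, and each carries an amide that links this core to a second aromatic ring carrying trifluoromethyl groups. Compound 1 `O=C(Nc1ccccc1C(F)(F)F)C1CCc2ccccc2N1` and compound 3 `O=C(Nc1cc(C(F)(F)F)cc(C(F)(F)F)c1)C1CCc2ccccc2N1` differ in that second ring; the difference between these two cores is not broken down here. Compound 2 `O=C(Nc1ccccc1C(F)(F)F)C1CCc2ccccc2N1C(=O)c1ccccc1` arises from compound 1 by one change, (benzoyl in place of hydrogen on a nitrogen on an aromatic ring in a ring). Compound 4 `O=C(Nc1cc(C(F)(F)F)cc(C(F)(F)F)c1)C1CCc2ccccc2N1C(=O)c1ccccc1` arises from compound 3 by the same change, (benzoyl in place of hydrogen on a nitrogen on an aromatic ring in a ring), at the same place.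

In a functional assay on NCI-H23 cells (Homo sapiens) for cytotoxicity, read by sulforhodamine B assay, with a stated time of 72 h (a lower number here means a stronger inhibitor of growth, a higher number a weaker inhibitor of growth), compound 1 gives 56800 nM. Compound 2 gives 6340 nM in this assay, so that the benzoyl group brought a 9.0-fold lower number from compound 1 to compound 2 (0.95 log units; beyond the scatter). Compound 3 gives 8410 nM in this assay, which lies within the scatter of the value of compound 2 and is a lower number than that of compound 1.

Whether the benzoyl group helps compound 3 as much as it helped compound 1 is the open question, and among these compounds the change has been seen only once. For compound 4 a step of about a 5.6-fold lower number from compound 3 to compound 4 (0.75 log units; beyond the scatter) is expected, somewhat smaller than before, because the earlier change gave a 9.0-fold lower number from compound 1 to compound 2 (0.95 log units; beyond the scatter) while compound 3 starts from 8410 nM, a lower number with less room for the same gain. Compound 4 is therefore estimated at 1500 nM in this assay, expected to fall between 400 nM and 6000 nM.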

Compound 4, concentration for 50% growth inhibition: 2130 nM
Beside the measured number, compound 4's estimate is 1.4-fold (0.15 log units) below it; the measured number falls inside the stated range.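

In this assay, putting benzoyl in place of hydrogen on the ring nitrogen again gives a lower number, a 3.9-fold lower number from compound 3 to compound 4 (0.60 log units; beyond the scatter), and this second step can be set against the first: the same change on two cores in this assay, a 9.0-fold lower number (0.95 log units; beyond the scatter) from compound 1 to compound 2 and a 3.9-fold lower number (0.60 log units; beyond the scatter) from compound 3 to compound 4, 2.3-fold (0.36 log units) apart, within the scatter of two such steps

Within this small set, the change therefore carries over from one core to the other: it points the same way on both, and the two steps cannot be told apart in size, so the smaller figure for the second pair should not be read as a real loss of effect. Within the data shown here, this is still only two pairs in a single cell assay, so it does not show that the change would act alike on any other core, and it gives no explanation of why the benzoyl group goes with a lower number.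

The compounds shown leave open whether a smaller acetyl group, a benzyl group or a longer chain on that same nitrogen would give a similar step, and whether a benzoyl ring carrying an amine or a carboxylic acid would keep it. They also leave open whether the step would appear in other cell lines, or whether it belongs to these cells alone.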